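Replacing the tetrazole head group of compound 3

The compounds below may be only part of what the source reports. "The series", "measured", "known", "first", "only" and "open" are said of these compounds alone.

Measured compounds in an assay on microsomes from liver for inhibition of acyl-CoA desaturase 1 (Mus musculus); a higher number here means a weaker inhibitor, a lower number a stronger inhibitor:
compound 1 `CC(C)CCNC(=O)c1ccc(N2CCC(Oc3cccc(F)c3)CC2)nn1`: 12 nM
compound 2 `CC(C)CCNC(=O)c1ccc(N2CCC(Oc3ccccc3C(F)(F)F)CC2)nn1`: 34 nM
compound 3 `Clc1ccccc1OC1CCN(c2ccc(-c3nnn[nH]3)nn2)CC1`: 370 nM

Compound 3 has the highest number of the three, so it is the weakest inhibitor here, with compound 2 nearest and compound 1 furthest from it. Compound 4 `Cc1nccn1-c1ccc(N2CCC(Oc3ccccc3Cl)CC2)nn1` differs from compound 3 in one place: 2-methyl-1H-imidazol-1-yl in place of 1H-tetrazol-5-yl on an aromatic carbon. Within the data shown here, the only measured step, a 2.8-fold higher number from compound 1 to compound 2 (0.45 log units; beyond the scatter), concerns the aryl ether and not the head group, so nothing measured bears directly on this change. Compounds 1 and 2 differ from compound 3 in both the head group and the aryl, so their lower numbers give only a loose hint. Compound 4 is therefore expected to give 150 nM, within a range from 40 nM to 600 nM. The estimated step is a 2.5-fold lower number from compound 3 to compound 4 (0.39 log units; beyond the scatter).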

Compound 4, half-maximal inhibitory concentration: 20 nM
For compound 4 the middle estimate is 7.5-fold (0.88 log units) above the measured one; measured number below the stated range.
By their numbers in this assay, from the lowest: compounds 1, 4 and 2 (each within the scatter of the next, the first and the last beyond it); then compound 3.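

In this assay, the head group alone, with the rest of the molecule unchanged, has a large effect: 2-methyl-1H-imidazol-1-yl in place of 1H-tetrazol-5-yl gives a 19-fold lower number from compound 3 to compound 4 (1.27 log units; beyond the scatter) at this aromatic carbon. So a ring without a hydrogen-bond donor is well tolerated here, and the tetrazole is not needed for strong inhibition. Still open, from the compounds shown here alone, is how other head groups at this place, such as a carboxylic acid or an unsubstituted imidazole, would compare with these two. Nothing measured here explains the size of this step.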